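Aryl replacement on the ring nitrogen: compound 2 to compound 4

This account rests on a few compounds, and the source may have more. Where it says the series, first, only, none or still open, it means among the compounds named here.

Working notes on a small series sharing one core, which differ only in the aryl group on a ring nitrogen. Compound 1 `CC1(C)[C@H]2CC[C@]1(C)N(Cc1cn(-c3ccc(Cl)cc3)nn1)C(=O)C2` carries a 4-chlorophenyl there; in a functional assay on SGC-7901 cells (Homo sapiens) for inhibition, read by MTT assay, with a stated time of 24 h (a lower number here means a stronger inhibitor, a higher number a weaker inhibitor), compound 1 gives 410 nM. Compound 2 `CC1(C)[C@H]2CC[C@]1(C)N(Cc1cn(-c3ccccc3Br)nn1)C(=O)C2` carries a 2-bromophenyl, and in this assay compound 2 gives 500 nM. Compound 3 `CC1(C)[C@H]2CC[C@]1(C)N(Cc1cn(-c3ccc(C#N)cc3)nn1)C(=O)C2` carries a 4-cyanophenyl, and in this assay compound 3 gives 500 nM. Compound 2 stands level with compound 3 at the digits shown, the two together the highest of the three numbers; the step of a 1.2-fold higher number from compound 1 to compound 2 (0.09 log units; within the scatter) is within the scatter, as is no change at the digits printed from compound 2 to compound 3 (within the scatter), and so is a 1.2-fold higher number from compound 1 to compound 3 (0.09 log units; within the scatter).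

Compound 4 `Cc1cccc(-n2cc(CN3C(=O)C[C@@H]4CC[C@@]3(C)C4(C)C)nn2)c1` differs from compound 2 by 3-methylphenyl in place of 2-bromophenyl on an aromatic nitrogen. Every measured step here is an exchange of the aryl group on that same ring nitrogen, or of its substituent, and none of them moved the number beyond the scatter. Accordingly the step of no change at the digits printed from compound 2 to compound 4 (within the scatter) is expected to be no change beyond the scatter. Compound 4 is therefore estimated at 500 nM, with a range from 250 nM to 1000 nM.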

Compound 4, half-maximal inhibitory concentration: 410 nM
Compound 4: middle estimate off by 1.2-fold (0.09 log units), on the high side, within the range that was stated.
By their numbers in this assay, from the lowest: compounds 1, 4, 2 and 3 (each within the scatter of the next).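

Within the data shown here, compound 4 carries the only aryl group of the four built of carbon alone, and in this assay the exchange reads a 1.2-fold lower number from compound 2 to compound 4 (0.09 log units; within the scatter) against the bromine-bearing ring, a 1.2-fold lower number from compound 3 to compound 4 (0.09 log units; within the scatter) against the nitrile-bearing ring and no change at the digits printed from compound 1 to compound 4 (within the scatter) against the chlorine-bearing ring. Among these compounds, neither a halogen nor a nitrile on the phenyl ring is therefore needed to keep the number within the scatter of the others, and this holds across the 2-bromophenyl, 3-methylphenyl, 4-chlorophenyl and 4-cyanophenyl groups, with no compound going against it. Nothing on hand bears on why these four aryl groups read alike.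

Going by these compounds, the four compounds hold only phenyl rings with a single substituent on that ring nitrogen, so it stays open whether the same flat reading would hold for an unsubstituted phenyl, a pyridine ring, a benzyl group, or a phenyl ring carrying an amine or a carboxylic acid. Every step shown also lies at this one place, which leaves open whether a longer chain between the shared core and the five-membered ring, or any exchange within the core, would move the number beyond the scatter.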